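The compounds below may be only part of what the source reports. "The series", "measured", "known", "first", "only" and "open" are said of these compounds alone.

Measured in an ADME assay on HUVEC cells (Homo sapiens) for cytotoxicity, read by MTT assay, with a stated time of 48 h; on this read-out lower numbers stand for stronger inhibition and higher numbers for weaker inhibition:
- compound 1 `O=C(NCCOC(=S)Nc1ccc(F)cc1)c1cccnc1`: 692000 nM
- compound 2 `O=C(CCCCC1CCSS1)OCCCOC(=O)c1cccnc1`: > 800000 nM

The entry for compound 2 is a limit of the assay, not a number. Going by the values given here, that leaves compound 1 at 692000 nM as the only number in this assay.

Compound 3 `COc1ccc(NC(=S)OCCNC(=O)c2cccnc2)cc1` differs from compound 1 in one place: methoxy in place of fluoro on an aromatic carbon, para to a large group. Among the compounds with values here, no measured step exists for comparison, and no change beyond the usual scatter is expected in this assay. The expected change is a 1.2-fold lower number from compound 1 to compound 3 (0.06 log units; within the scatter). The only anchor for this expectation is compound 1 at 692000 nM. Compound 3 is expected at 600000 nM, with an estimated range of 250000 nM to 900000 nM.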

Compound 3, half-maximal inhibitory concentration: 550000 nM
The estimate for compound 3 lay 1.1-fold (0.04 log units) above the measured number; measured number inside the range.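

In this assay, going by these compounds alone, the first single-place comparison gives a 1.3-fold lower number from compound 1 to compound 3 (0.10 log units; within the scatter), for methoxy in place of fluoro on an aromatic carbon, para to a large group. At this position, then, the exchange of these two groups does not move the number beyond the scatter. Compound 2 gives a limit of the assay, not a number, and adds no step: the limit of > 800000 nM in this assay, at which 1 of the 3 values shown sits.

From the compounds shown here alone, whether an amine or a carboxylic acid at this position would shift the number beyond the scatter remains open. So does the effect of a change elsewhere on the shared core.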